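From 4-methylphenyl to 3,5-dimethylphenyl on the shared core

The source may hold more compounds than are shown below. What is called first, only, known or untested is meant among the compounds shown, and "the series" means these compounds.

Compound 1 `COC(=O)/C=C/c1ccc2c(c1)C(=O)C(=O)N2Cc1ccc(C#N)cc1` gives 80 nM
Compound 2 `COC(=O)/C=C/c1ccc2c(c1)C(=O)C(=O)N2Cc1ccc(C)cc1` gives 50 nM

In a functional assay on Jurkat cells (Homo sapiens) for antiproliferative activity, read by MTT assay, with a stated time of 48 h (on this read-out higher numbers stand for weaker inhibition and lower numbers for stronger inhibition), compound 2 gives 50 nM and lies within the scatter of compound 1 at 80 nM on these two numbers. Compound 3 `COC(=O)/C=C/c1ccc2c(c1)C(=O)C(=O)N2Cc1cc(C)cc(C)c1` has not yet been measured. The change from compound 2 is 3,5-dimethylphenyl in place of 4-methylphenyl on a saturated chain carbon bound to an amide-type nitrogen in a ring and amounts to 3,5-dimethylphenyl in place of 4-methylphenyl on a saturated chain carbon bound to an amide-type nitrogen in a ring. Going by the values given here, only one measured step bears on it, and only loosely: a 1.6-fold lower number from compound 1 to compound 2 (0.20 log units; within the scatter) with methyl in place of cyano on an aromatic carbon. Among the compounds with values here, no measured pair tests this exact change, so no shift beyond the scatter is expected in this assay and the direction stays open. The estimated step of a 1.3-fold lower number from compound 2 to compound 3 (0.10 log units; within the scatter) is expected to remain small. Compound 3 is expected at 40 nM with an estimated range of 15 nM to 110 nM.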

Compound 3, half-maximal inhibitory concentration: 620 nM
Beside the measured number, compound 3's estimate is 16-fold (1.19 log units) below it; measured number above the stated range.
By their numbers in this assay, from the lowest: compounds 2 and 1 (each within the scatter of the next); then compound 3.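

In this assay, 3,5-dimethylphenyl in place of 4-methylphenyl gives a 12-fold higher number from compound 2 to compound 3 (1.09 log units; beyond the scatter), so this place on the saturated chain carbon bound to an amide-type nitrogen in a ring is sensitive to the aryl group, which the methyl-for-cyano step within the scatter had not revealed. Measured against 4-cyanophenyl, the same group gives a 7.8-fold higher number from compound 1 to compound 3 (0.89 log units; beyond the scatter), which sets 3,5-dimethylphenyl apart from both 4-substituted phenyl groups in this small set. Nothing available here accounts for this loss of activity.

The compounds shown do not separate the effect of adding a second methyl from that of moving away from the 4-methylphenyl arrangement, as the two changes come together in compound 3. As far as these compounds go, how an unsubstituted phenyl group or a chain ending in an amine would read at this place also remains open.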